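The source may report more compounds than this note shows. Statements on the series, on what has been measured and on what is new or still open speak of the compounds shown alone.

In a functional assay on the whole organism with Rattus norvegicus as the target (a lower number here means that less compound is needed, a higher number that more compound is needed for the effect), compound 1 `CCOC(=O)C(=O)Nc1ccc(N)cc1C#N` gives 8.8 mg/kg, compound 2 `CNc1cccc(NC(=O)C(=O)O)c1C#N` gives 0.07 mg/kg, and compound 3 `CCCCNc1cccc(NC(=O)C(=O)OCC)c1C#N` gives 0.3 mg/kg. Compound 3 therefore stands between the other two on this assay, closer to compound 2 than to compound 1, and both of those gaps lie beyond the scatter. Compound 4 `CCOC(=O)C(=O)Nc1cccc(F)c1C#N` differs from compound 3 in one place: fluoro in place of butylamino on an aromatic carbon. For the measured compounds named here, no measured pair shows this change, so the step from compound 3 to compound 4 can only be estimated. Going by the values given here, because compound 1, the only other compound without a butylamino group, gives 8.8 mg/kg, compound 4 is expected to need more compound than compound 3, by a 6.7-fold higher number from compound 3 to compound 4 (0.82 log units; beyond the scatter). On that basis compound 4 is estimated at 2 mg/kg, in a range from 0.4 mg/kg to 10 mg/kg.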

Compound 4, dose for half-maximal effect: 59 mg/kg
The estimate for compound 4 lay 30-fold (1.47 log units) below the measured number, and the stated range ends below it.
By their numbers in this assay, from the lowest: compound 2; then compound 3; then compound 1; then compound 4.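

In this assay the exchange of butylamino for fluoro at this aromatic carbon, ortho to a cyano group, gives a 200-fold higher number from compound 3 to compound 4 (2.29 log units; beyond the scatter) and is a large change beyond the scatter. For the compounds shown here, this is the first single-place comparison, and it shows that the number at this position depends strongly on the group placed there. Nothing available explains the size of this step. The compounds shown leave open whether the low number follows the amine nitrogen or the butyl chain. A dimethylamino, a hexylamino or a methoxy group at this carbon could help separate those possibilities.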